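From 3,5-Dimethylbenzyl to 2-Methoxybenzyl: Expecting Compound 4

A few compounds are considered here, and "the series" means these few. Any claim that something is new, unique, unknown or untested is made for them only; others in the source may bear on it.

Measured so far in a functional assay on MCF7 cells (Homo sapiens) for antiproliferative activity, read by sulforhodamine B assay, with a stated time of 72 h; a higher number here means a weaker inhibitor, a lower number a stronger inhibitor:
- compound 1 `Cc1cccc(COc2ccc(-c3cc(CN4CCN(Cc5ccc(C(F)(F)F)cc5)CC4)no3)cc2)c1` gives 4000 nM
- compound 2 `Cc1cc(C)cc(COc2ccc(-c3cc(CN4CCN(Cc5ccc(C(F)(F)F)cc5)CC4)no3)cc2)c1` gives 1600 nM
- compound 3 `FC(F)(F)c1ccc(CN2CCN(Cc3cc(-c4ccc(OCc5cccc(Cl)c5)cc4)on3)CC2)cc1` gives 1400 nM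

Compound 2 stands second highest of the three numbers; its step to compound 3 is a 1.1-fold lower number from compound 2 to compound 3 (0.06 log units; within the scatter), and its step from compound 1 is a 2.5-fold lower number from compound 1 to compound 2 (0.40 log units; beyond the scatter). Compound 4 `COc1ccccc1COc1ccc(-c2cc(CN3CCN(Cc4ccc(C(F)(F)F)cc4)CC3)no2)cc1` is not yet measured. It differs from compound 2 by 2-methoxyphenyl in place of 3,5-dimethylphenyl on a saturated chain carbon bound to an oxygen on an aromatic ring.

Going by the values given here, no measured step involves a methoxy group, so the bearing steps are indirect: they show that changing the group on this ring moves the number by modest amounts, as in a 2.5-fold lower number from compound 1 to compound 2 (0.40 log units; beyond the scatter) and a 2.9-fold lower number from compound 1 to compound 3 (0.46 log units; beyond the scatter), while a 1.1-fold lower number from compound 2 to compound 3 (0.06 log units; within the scatter) shows two different groups giving the same number. For compound 4 a step no larger than these is expected, most likely toward a somewhat higher number, so that a 1.9-fold higher number from compound 2 to compound 4 (0.27 log units; within the scatter) is the estimated change. Compound 4 is therefore expected to give about 3000 nM in this assay, within the range 1200 nM to 8000 nM.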

Compound 4, half-maximal inhibitory concentration: 300 nM
Compound 4: middle estimate off by 10-fold (1.00 log units), on the high side, and the stated range ends above it.
By their numbers in this assay, from the lowest: compound 4; then compounds 3 and 2 (each within the scatter of the next); then compound 1.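

In this assay, the group on this saturated chain carbon can do more than the first three compounds suggested: 2-methoxyphenyl gives a 5.3-fold lower number from compound 2 to compound 4 (0.73 log units; beyond the scatter) and a 4.7-fold lower number from compound 3 to compound 4 (0.67 log units; beyond the scatter), although compounds 2 and 3 sat within the scatter of each other. It also gives a 13-fold lower number from compound 1 to compound 4 (1.12 log units; beyond the scatter), which makes compound 4 the strongest inhibitor of the four. Going by these compounds alone, this is the first group here with an oxygen on the benzyl ring and a hydrogen-bond acceptor, but nothing available explains the drop in the number.

The compounds shown leave open whether the gain follows the methoxy group itself or its place on the ring. Compounds with 3-methoxyphenyl, 4-methoxyphenyl, 2-methylphenyl or 2-hydroxyphenyl at this site would separate those possibilities.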